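The source may hold more compounds than are shown below. What is called first, only, known or untested is meant among the compounds shown, and "the series" means these compounds.

Measured so far in an ADME assay on HEL cells (Homo sapiens) for cytotoxicity, with a stated time of 3 days; on this read-out higher numbers stand for lower toxicity in this test and lower numbers for higher toxicity in this test:
compound 1 `Cc1cc(-c2cccc(F)c2)c2ncc(CSCCc3ccccc3)n2c1` gives 35 ug/mL
compound 2 `Cc1cc(-c2ccc(C#N)cc2)cn2c(CSCCc3ccccc3)cnc12` gives 10.6 ug/mL
compound 3 `Cc1cc(-c2cccs2)c2ncc(CSCCc3ccccc3)n2c1` gives > 50 ug/mL, a limit of the assay, not a number

Compound 2 stands at the lower of the two numbers; compound 1 sits higher, and that gap lies beyond the scatter of repeated measurements. Compound 3 reports only a limit: the limit of > 50 ug/mL in this assay, at which 1 of the 3 values shown sits. Among the measured compounds shown here, the one step between neighbours, an at least 1.4-fold higher number from compound 1 to compound 3 (0.15 log units; that floor lies within the scatter), exchanges the whole aryl ring and sets only a floor that lies within the scatter.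

Compound 4 `COc1ccc(-c2cc(C)c3ncc(CSCCc4ccccc4)n3c2)cc1` differs from compound 2 at that same ring: methoxy in place of cyano on an aromatic carbon. For the measured compounds named here, no measured step exchanges one substituent for another on the six-membered ring; the step from compound 1 to compound 3 replaces the ring and gives no direction to lean on. What the two numbers from compound 2 and compound 1 do show is that a change on this ring can move the read-out beyond the scatter. The expected step is a 2.1-fold higher number from compound 2 to compound 4 (0.32 log units; beyond the scatter), a modest rise towards the value of compound 1, held loosely. For compound 4 the estimate in this assay is 22 ug/mL, between 8 ug/mL and 50 ug/mL.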

Compound 4, half-maximal cytotoxic concentration: 25.8 ug/mL
The estimate for compound 4 lay 1.2-fold (0.07 log units) below the measured number; the range from low to high includes it.
By their numbers in this assay, from the lowest: compound 2; then compounds 4 and 1 (each within the scatter of the next). At a limit, above all of these: compound 3.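

In this assay, among the compounds shown here, this is the first exchange of one substituent for another on the six-membered ring with the ring itself kept: 4-cyanophenyl to 4-methoxyphenyl gives a 2.4-fold higher number from compound 2 to compound 4 (0.39 log units; beyond the scatter). The read-out therefore responds to a single group at this place, even though the heavy-atom and hydrogen-bond acceptor counts stay the same across the change. Compound 3 still reports only a limit of the assay, and the number for compound 4 does not join it: the limit of > 50 ug/mL in this assay, at which 1 of the 4 values shown sits.

Compound 2 remains the only compound shown with cyano, so the data cannot say whether its lower number belongs to cyano in particular or whether methoxy is simply one of many groups that would give a higher number at this place. As far as these compounds go, what an amine, a carboxylic acid or a longer alkoxy chain would give on the same aromatic carbon stays open, as does whether methoxy would produce a step of similar size on the 3-fluorophenyl or thiophen-2-yl compounds.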